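The compounds below may be only part of what the source reports. "The series", "measured", "known", "first", "only" and "open" are said of these compounds alone.

Of the compounds shown here, three have been measured in an assay on membranes from liver for displacement of a labelled ligand from Sigma intracellular receptor 2 (Rattus norvegicus), read by scintillation counting, with a stated time of 120 min, in the presence of a further agent that is not named here; on this read-out higher numbers stand for weaker inhibition and lower numbers for stronger inhibition. Compound 1 `O=c1oc(-c2ccccc2)nn1CCCCN1CCc2ccc([N+](=O)[O-])cc2C1` gives 383 nM. Compound 2 `Cc1ccc(CN(C)CCCCn2nc(-c3ccccc3)oc2=O)c(C)c1` gives 21 nM. Compound 3 `O=C1CCc2ccccc2N1CCCCN1CCN(C2CCCCC2)CC1` gives 1.5 nM, the lowest number of the three, and so the strongest inhibition in this set; its nearest neighbour is compound 2, whose number is higher by more than the usual scatter, and compound 1 lies much further away still.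

The next compound, compound 4 `O=C1CCc2ccccc2N1CCCCN1CCN(c2ccccn2)CC1`, keeps the whole core of compound 3 and changes one group: pyridin-2-yl in place of cyclohexyl on an amine nitrogen in a ring. Among the measured compounds shown here, no measured pair in this set shows that particular exchange, so the size of its effect is not known from these data. The rings that leave and enter are both six-membered, but one is a saturated ring of carbon only and the other an aromatic ring with one hetero atom and one hydrogen-bond acceptor.

For compound 4 the expectation is a moderately higher number than for compound 3, that is a step of a 5.3-fold higher number from compound 3 to compound 4 (0.73 log units; beyond the scatter), beyond the scatter but leaving compound 4 well below compound 1 and probably near compound 2. The estimate for compound 4 in this assay is 8 nM, within a range of 2 nM to 40 nM.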

Compound 4, inhibition constant: 73 nM
Beside the measured number, compound 4's estimate is 9.1-fold (0.96 log units) below it; measured number above the stated range.
By their numbers in this assay, from the lowest: compound 3; then compound 2; then compound 4; then compound 1.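

In this assay, the group on this ring nitrogen matters a great deal: pyridin-2-yl in place of cyclohexyl gives a 49-fold higher number from compound 3 to compound 4 (1.69 log units; beyond the scatter) and therefore much weaker inhibition. Among the compounds shown here, this is the first one-place comparison in the set, and it shows that two six-membered rings with the same number of heavy atoms are far from interchangeable here, even though the rest of the molecule stays the same. No measurement shown accounts for the size of this step.

This single exchange changes a saturated carbon ring into an aromatic ring with one hetero atom, so it cannot show which of these differences matters. A tetrahydropyran-4-yl or pyrimidin-2-yl group at this position would help to separate them, but the compounds shown leave this open.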